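The source may hold more compounds than are shown below. What is called first, only, known or untested is meant among the compounds shown, and "the series" means these compounds.

Going by the values given here, compound 2 `COc1ccc(F)cc1-c1cccc(-c2nn(CCOC3CCCCO3)c(=O)o2)c1` stands at the lower of the two numbers measured so far: in a functional assay on the whole organism (strain Wistar albino) for inhibition, with Rattus norvegicus as the target, read by paw edema, with stated times of 30 min and 0.5 h, at a dose of 10 mg/kg by the oral route (on this read-out lower numbers stand for less inhibition and higher numbers for more inhibition at the one dose given (going by the name of the read-out)), compound 2 gives 16%, while compound 1 `COc1ccc(F)cc1-c1cccc(-c2nn(CCCC#N)c(=O)o2)c1` gives 29%, the step between them being a number 13 percentage points lower from compound 1 to compound 2 (beyond the scatter). Compound 3 `COc1ccc(F)cc1-c1cccc(-c2nn(CCO)c(=O)o2)c1` differs from compound 2 in one place: hydrogen in place of oxan-2-yl on an oxygen on a saturated carbon. Among the compounds with values here, no measured step covers this exchange; the only step known, a number 13 percentage points lower from compound 1 to compound 2 (beyond the scatter), concerns a different group on the same chain. The expected change from compound 2 to compound 3 is therefore a number 6 percentage points higher from compound 2 to compound 3 (within the scatter), not beyond the scatter. Compound 3 is estimated at 22%, between 8% and 38%.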

Compound 3, a percentage reported as inhibition, in the whole organism at one dose (the size of the read-out at that dose, not a potency): 28%
The estimate for compound 3 lay 6 percentage points below the measured number, within the range that was stated.
By their numbers in this assay, from the lowest: compound 2; then compounds 3 and 1 (each within the scatter of the next).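

In this assay the exchange at this oxygen, hydrogen in place of oxan-2-yl, gives a number 12 percentage points higher from compound 2 to compound 3 (beyond the scatter) and so separates the free 2-hydroxyethyl chain from the 2-((oxan-2-yl)oxy)ethyl chain. Hydroxy and cyanomethyl on the chain cannot be told apart, with a number 1 percentage points lower from compound 1 to compound 3 (within the scatter) as the step between them. Nothing available explains either step.

As far as these compounds go, whether an amine or a carboxylic acid in place of the hydroxy would change the number remains open. So does the effect of a longer chain carrying the same hydroxy.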